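The compounds below may be only part of what the source reports. "The series", "measured", "known", "first", "only" and "open" are said of these compounds alone.

Measured so far:
- compound 1 `CC(C(=O)NCc1ccc(C(F)(F)F)nc1SCCOc1ccccc1)c1ccc(NS(C)(=O)=O)c(F)c1`: 2.3 nM
- compound 2 `CC(C(=O)NCc1ccc(C(F)(F)F)nc1SCCC(=O)O)c1ccc(NS(C)(=O)=O)c(F)c1`: "not active" (no number reported)

For the measured compounds named here, in an assay on CHO-K1 cells for antagonist activity at transient receptor potential cation channel subfamily V member 1 (Homo sapiens), read by FLIPR (a higher number here means a weaker inhibitor, a lower number a stronger inhibitor), compound 1 gives 2.3 nM, the only number available in this set, and so compound 1 stands alone as the reference point. Compound 2 is reported in this assay as "not active" (no number reported), so no number is available for it and nothing about the size of any step between compound 1 and compound 2 can be stated.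

Compound 3 `Cc1ccc(CSc2nc(C(F)(F)F)ccc2CNC(=O)C(C)c2ccc(NS(C)(=O)=O)c(F)c2)cc1` differs from compound 1 in one place: 4-methylphenyl in place of phenoxymethyl on a saturated chain carbon bound to a sulfur. One aromatic ring replaces another on the chain bound to the sulfur, and the single hydrogen-bond acceptor of the leaving group is lost.

Going by the values given here, with no measured step of this kind to lean on, compound 3 is expected to remain a strong inhibitor, with a step from compound 1 of a 2.2-fold higher number from compound 1 to compound 3 (0.34 log units; beyond the scatter) toward slightly weaker inhibition, at most around the edge of the scatter. Compound 3 is thus estimated at 5 nM, with a range from 1.5 nM to 20 nM.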

Compound 3, inhibition constant: 3.2 nM
Estimate against measurement, compound 3: 1.6-fold (0.19 log units) above; the range from low to high includes it.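

Putting 4-methylphenyl in place of phenoxymethyl on a saturated chain carbon bound to a sulfur gives, in this assay, a 1.4-fold higher number from compound 1 to compound 3 (0.14 log units; within the scatter). For the compounds shown here, this is the first numerical comparison at this position, and it shows that two different ring-bearing groups can sit there with no difference that this measurement can resolve, even though 4-methylphenyl carries no hydrogen-bond acceptor and phenoxymethyl carries one. No measurement shown here explains why the two compounds read alike.

The compounds shown leave open whether an aromatic ring is needed at this position at all, since neither a plain butyl chain nor an amine at the end of the chain appears among them. They also leave open how a ring such as pyridine, or a substituent such as chlorine in place of the methyl of 4-methylphenyl, would read.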